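Series notes: carboxy in place of chloro

The compounds below may be only part of what the source reports. "The series", "measured", "known", "first", "only" and "open" are said of these compounds alone.

In a physicochemical assay for solubility, read by spectrophotometry, in phosphate buffer, with a stated time of 18 h, at pH 7.4 (a higher number here means a more soluble compound, a lower number a less soluble compound), compound 1 (`CCc1ccc(-c2nc3c(c(C)nn3-c3ccccc3)c(-c3ccccc3O)c2C#N)cc1`) gives 3100 nM and compound 2 (`CCc1ccc(-c2nc3c(c(C)nn3-c3ccccc3)c(-c3ccccc3[N+](=O)[O-])c2C#N)cc1`) gives 1200 nM. Compound 3 (`CCc1ccc(-c2nc3c(c(C)nn3-c3ccccc3)c(-c3ccccc3Cl)c2C#N)cc1`) gives 1700 nM, within the scatter of both other compounds. Compound 4 (`CCc1ccc(-c2nc3c(c(C)nn3-c3ccccc3)c(-c3ccccc3C(=O)O)c2C#N)cc1`) has carboxy in place of chloro on an aromatic carbon, ortho to a large group: carboxy in place of chloro on an aromatic carbon. The measured steps at this place are small. a 1.8-fold lower number from compound 1 to compound 3 (0.26 log units; within the scatter) and a 1.4-fold higher number from compound 2 to compound 3 (0.15 log units; within the scatter) stay within the scatter, and only a 2.6-fold lower number from compound 1 to compound 2 (0.41 log units; beyond the scatter) goes beyond it, modestly. None of them introduces carboxy, so they constrain this change poorly. A rise in this assay larger than these steps is expected, though with a wide range. The expected step is a 5.9-fold higher number from compound 3 to compound 4 (0.77 log units; beyond the scatter). For compound 4 the estimated value is 10000 nM, with an expected range of 2500 nM to 40000 nM.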

Compound 4, solubility: 33000 nM
The estimate for compound 4 lay 3.3-fold (0.52 log units) below the measured number; measured number inside the range.
By their numbers in this assay, from the lowest: compounds 2, 3 and 1 (each within the scatter of the next, the first and the last beyond it); then compound 4.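

In this assay this position proves far more responsive than the hydroxy, nitro and chloro compounds indicated: carboxy gives large rises over all three (a 19-fold higher number from compound 3 to compound 4 (1.29 log units; beyond the scatter); a 28-fold higher number from compound 2 to compound 4 (1.44 log units; beyond the scatter); an 11-fold higher number from compound 1 to compound 4 (1.03 log units; beyond the scatter)). Going by these compounds alone, each rise exceeds every step among the earlier compounds, leaving compound 4 alone at the top of the four. Nothing available accounts for the size of the rise.

From the compounds shown here alone, whether the rise requires the free carboxylic acid remains open. A methyl ester or a primary amide at this place would separate the acid from other carbonyl groups.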